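The compounds below may be only part of what the source reports. "The series", "measured", "known", "first", "only" and "open" are said of these compounds alone.

Compound 1, with the structure `CCCn1c(=O)c2nc(-c3cnn(Cc4cccc(C)c4)c3)[nH]c2n(CCC)c1=O`, gives 36 nM in an in vitro assay on HEK293 cells for displacement of a labelled ligand from adenosine receptor A2b (Homo sapiens) (a lower number here means a stronger inhibitor, a higher number a weaker inhibitor), the lowest of the two numbers measured here. Compound 2, `CCCCn1c(=O)c2nc(-c3cnn(Cc4ccccc4)c3)[nH]c2n(CCCC)c1=O`, gives 980 nM in this assay, a much higher number, and that gap lies beyond the usual scatter. Compound 3, `CCCn1c(=O)c2c(nc(-n3cc(I)cn3)n2Cc2ccccc2)n(CCC)c1=O`, reaches only the limit of > 5800 nM in this assay, which is a limit of the assay and not a number. The step followed here runs from compound 1 to compound 4, `CCCn1c(=O)c2nc(-c3cnn(Cc4ccc(F)c(C(F)(F)F)c4)c3)[nH]c2n(CCC)c1=O`, where the change is 4-fluoro-3-(trifluoromethyl)phenyl in place of 3-methylphenyl on a saturated chain carbon bound to an aromatic nitrogen. No measured pair shows a step of this kind in this assay, so its size is a guess; a small rise in the number, expected at about a 1.5-fold higher number from compound 1 to compound 4 (0.18 log units; within the scatter), seems most likely. Compound 4 is therefore estimated at 55 nM, with an expected range from 15 nM to 220 nM.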

Compound 4, inhibition constant: 640 nM
For compound 4 the middle estimate is 12-fold (1.07 log units) below the measured one, and the stated range ends below it.
By their numbers in this assay, from the lowest: compound 1; then compounds 4 and 2 (each within the scatter of the next). At a limit, above all of these: compound 3.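

In this assay, replacing 3-methylphenyl with 4-fluoro-3-(trifluoromethyl)phenyl on a saturated chain carbon bound to an aromatic nitrogen gives an 18-fold higher number from compound 1 to compound 4 (1.25 log units; beyond the scatter). The six-membered aromatic ring stays and only its substituents change, yet this alone makes the number much higher, so this position responds strongly to such a change. Nothing measured here explains the rise. On these data alone, the fluorine and the trifluoromethyl enter together, so their separate contributions remain unknown. A phenyl carrying only a trifluoromethyl, or only a fluorine, could separate them.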